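A change on the triazole nitrogen of compound 2

The compounds below may be only part of what the source reports. "The series", "measured", "known", "first", "only" and "open" are said of these compounds alone.

Compound 2 `COc1cc2c(Oc3ccc(NC(=O)c4cn(-c5c(C)cccc5C)nn4)cc3F)ccnc2cc1OCCCN1CCN(C)CC1` gives 2180 nM in a functional assay on A549 cells (Homo sapiens) for cytotoxicity, read by MTT assay, with a stated time of 72 h (on this read-out higher numbers stand for weaker inhibition and lower numbers for stronger inhibition), the higher of the two numbers here. Among the measured compounds shown here, compound 1 `COc1cc2c(Oc3ccc(NC(=O)c4cn(-c5ccc(F)c(F)c5)nn4)cc3F)ccnc2cc1OCCCN1CCCCC1` gives 220 nM in this assay, though it differs from compound 2 in two places, so no single step connects them. Compound 3 `COc1cc2c(Oc3ccc(NC(=O)c4cn(-c5ccc(F)c(F)c5)nn4)cc3F)ccnc2cc1OCCCN1CCN(C)CC1` carries 3,4-difluorophenyl in place of 2,6-dimethylphenyl on an aromatic nitrogen, the same group that compound 1 bears. The step from compound 2 to compound 3 is therefore expected to lower the number beyond the scatter, a 4.4-fold lower number from compound 2 to compound 3 (0.64 log units; beyond the scatter) in this assay. Compound 3 is estimated at 500 nM, within 150 nM to 1600 nM.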

Compound 3, half-maximal inhibitory concentration: 200 nM
Compound 3: middle estimate off by 2.5-fold (0.40 log units), on the high side; low and high end bracket the measured number.
By their numbers in this assay, from the lowest: compounds 3 and 1 (each within the scatter of the next); then compound 2.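

In this assay, among the compounds shown here, 3,4-difluorophenyl in place of 2,6-dimethylphenyl on the aromatic nitrogen gives an 11-fold lower number from compound 2 to compound 3 (1.04 log units; beyond the scatter) as a large step, the first single-place reading at this position. On the saturated chain, 4-methylpiperazin-1-yl in place of piperidin-1-yl gives a 1.1-fold lower number from compound 1 to compound 3 (0.04 log units; within the scatter) with 3,4-difluorophenyl held constant, so this assay does not separate those two amines. Nothing on hand accounts for either step. On these data alone, whether the large step follows from adding the two fluorines or from removing the two methyl groups stays open. Unsubstituted phenyl or 4-methoxyphenyl on that nitrogen, or morpholine on the chain, would extend the comparison.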